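The source may hold more compounds than are shown below. What is called first, only, known or untested is meant among the compounds shown, and "the series" means these compounds.

Of the compounds shown here, three sharing one core have been tested in a functional assay on the whole organism (strain Swiss) for inhibition, with Mus musculus as the target, in the writhing test, with stated times of 30 min and 20 min, at a dose of 10 mg/kg by the intraperitoneal route; on this read-out higher numbers stand for more inhibition at the one dose given (going by the name of the read-out) and lower numbers for less inhibition. Compound 1 `Cc1c(N2C(=O)C(Cl)=C(Cl)C2=O)c(=O)n(-c2ccccc2)n1C` gives 99%. Compound 2 `Cc1c(N2C(=O)C(Cl)=C(Nc3cccc([N+](=O)[O-])c3)C2=O)c(=O)n(-c2ccccc2)n1C` gives 29.5%, and compound 3 `Cc1c(N2C(=O)C(Cl)=C(Nc3ccc(C(=O)O)cc3)C2=O)c(=O)n(-c2ccccc2)n1C` gives 63.6%. Compound 3 thus stands second highest of the three: compound 1 lies above it, the step being a number 35.4 percentage points lower from compound 1 to compound 3 (beyond the scatter), while compound 2 lies below it, the step being a number 34.1 percentage points higher from compound 2 to compound 3 (beyond the scatter).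

Compound 4 `Cc1c(N2C(=O)C(Cl)=C(Nc3ccc(Cl)c([N+](=O)[O-])c3)C2=O)c(=O)n(-c2ccccc2)n1C` has not been measured. It differs from compound 3 in one place: 4-chloro-3-nitrophenyl in place of 4-carboxyphenyl on an amine nitrogen. The measured step that bears most directly on this change is the one between the (3-nitrophenyl)amino and the (4-carboxyphenyl)amino compounds, a number 34.1 percentage points higher from compound 2 to compound 3 (beyond the scatter), which was large. Going by the values given here, compound 4 carries a nitro group again, as compound 2 does, together with chloro; no measured step shows what that chloro adds. Compound 4 is therefore expected to fall back toward the level of compound 2, an estimated step of a number 28.6 percentage points lower from compound 3 to compound 4 (beyond the scatter). In this assay compound 4 is estimated at 35%, with a range from 15% to 60%.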

Compound 4, a percentage reported as inhibition, in the whole organism at one dose (the size of the read-out at that dose, not a potency): 98.5%
Compound 4: middle estimate off by 63.5 percentage points, on the low side; measured number above the stated range.
By their numbers in this assay, from the lowest: compound 2; then compound 3; then compounds 4 and 1 (each within the scatter of the next).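

In this assay, a single chloro in place of hydrogen on an aromatic carbon is a step of a number 69 percentage points higher from compound 2 to compound 4 (beyond the scatter), so a nitro group on this phenyl ring does not by itself go with a low number. Changing the group on the amine nitrogen gives a number 34.9 percentage points higher from compound 3 to compound 4 (beyond the scatter), which places the 4-chloro-3-nitrophenyl compound above the 4-carboxyphenyl compound rather than below it. On the double-bonded ring carbon, the (4-chloro-3-nitrophenyl)amino group can stand in for chloro with a number 0.5 percentage points lower from compound 1 to compound 4 (within the scatter), so an arylamino group here need not lower the number, although in compound 2 and compound 3 it does.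

Still open, on these data alone, is whether the chloro does the same without the nitro, and whether bromo or methyl could take its place. Nothing measured here explains why this chloro matters so much.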